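A few compounds are considered here, and "the series" means these few. Any claim that something is new, unique, unknown or untested is made for them only; others in the source may bear on it.

Compound 1 `COc1ccc(C2N=C(SCc3ccc(Cl)cc3)NC(C)=C2C(=O)Nc2ccc(F)cc2)cc1OC` was tested in a functional assay on the whole organism (artery, strain albino) with Rattus norvegicus as the target, with a stated time of 720 min, at a dose of 10 mg/kg by the oral route (a higher number here means more inhibition at the dose given (going by the name of the read-out), a lower number less inhibition), and in it compound 1 gives 22.2%. Compound 2 `COc1ccc(C2N=C(SCc3ccc(F)cc3)NC(C)=C2C(=O)Nc2ccc(F)cc2)cc1OC` differs from compound 1 in one place: fluoro in place of chloro on an aromatic carbon. In this assay compound 2 gives 17%, which is a number 5.2 percentage points lower from compound 1 to compound 2 (within the scatter). Compound 3 `COc1ccc(C2N=C(SCc3ccc(Cl)cc3)NC(C)=C2C(=O)Nc2ccc(Br)cc2)cc1` shares much with compound 1, but the two differ in more than one place, and the difference between the two cores is not broken down here. In this assay compound 3 gives 23.7%; its number and those of compound 1 and compound 2 all lie within the usual scatter of one another, so no order among the three can be read from them. Compound 4 `COc1ccc(C2N=C(SCc3ccc(F)cc3)NC(C)=C2C(=O)Nc2ccc(Br)cc2)cc1` has not yet been measured. It differs from compound 3 by the same change that separates compound 1 from compound 2, at the same kind of place: fluoro in place of chloro on an aromatic carbon. The earlier instance of this change gave a number 5.2 percentage points lower from compound 1 to compound 2 (within the scatter). Resting on that single earlier step, the expected size of the change is a number 5.2 percentage points lower from compound 3 to compound 4 (within the scatter). The number for compound 4 in this assay is estimated at 18.5%, most likely between 8% and 29%.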

Compound 4, a percentage reported as inhibition, in the whole organism at one dose (the size of the read-out at that dose, not a potency): 19.1%
Estimate against measurement, compound 4: 0.6 percentage points below, within the range that was stated.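

In this assay, fluoro in place of chloro on the benzyl group gave a number 4.6 percentage points lower from compound 3 to compound 4 (within the scatter), and the two instances of this change can be set side by side: the same change on two cores in this assay, a number 5.2 percentage points lower (within the scatter) from compound 1 to compound 2 and a number 4.6 percentage points lower (within the scatter) from compound 3 to compound 4, 0.6 percentage points apart, within the scatter of two such steps

So the change carried from one core to the other with no visible difference in the size of the step, even though those cores differ in more than one place. Each step alone lies within the scatter, however, so neither shows that fluoro truly gives a different number from chloro, and two cores are too few to support a rule for the whole series.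

Only chloro and fluoro appear at this place in the compounds shown, so it remains open whether an amine or a carboxylic acid there, or a longer chain in place of the benzyl group, would give a step beyond the scatter. As far as these compounds go, what each difference between the two cores does on its own also remains open.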